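Two Ring Stereocentres Inverted: From Compound 1 to Compound 4

The source may report more compounds than this note shows. Statements on the series, on what has been measured and on what is new or still open speak of the compounds shown alone.

Compound 1 `C=C1CCCC(C)(C)C1CC[C@]1(C)CC[C@@H]([C@@H](C)C(=O)O)OO1`, 2720 nM
Compound 2 `C=C1CCCC(C)(C)C1(O)CC/C(C)=C/CC[C@]1(C)CC[C@@H]([C@@H](C)C(=O)OC)OO1`, > 17500 nM
Compound 3 `CC1=C(CC/C(C)=C/CC[C@@]2(C)CC[C@@H]([C@H](C)C(=O)O)OO2)C(C)(C)CCC1`, > 100000 nM

Of the compounds shown here, three have been measured in a functional assay on SR cells (Homo sapiens) for inhibition; a lower number here means a stronger inhibitor of growth, a higher number a weaker inhibitor of growth. Compound 1 gives 2720 nM and is the only one of the three with a number rather than a limit. For compound 2 this assay reports only a limit, > 17500 nM. For compound 3 likewise only a limit is reported, > 100000 nM. Two of the three values therefore sit at a limit: the limit of > 100000 nM in this assay, at which 1 of the 3 values shown sits, and (the limit of > 17500 nM in this assay, at which 1 of the 3 values shown sits). No pair among these three compounds differs in a single place, so no measured step is available to lean on.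

Compound 4 `C=C1CCCC(C)(C)C1CC[C@@]1(C)CC[C@H]([C@@H](C)C(=O)O)OO1` has not yet been measured in this assay. It differs from compound 1 as follows: the two compounds have the same atoms and bonds; at least one stereo element is drawn with a configuration in one of them and without one in the other: 2 of 4 stereo elements differ; a stereocentre at a saturated ring carbon is drawn R in compound 1 and S in compound 4; a stereocentre at a saturated ring carbon is drawn S in compound 1 and R in compound 4. Two stereocentres at saturated ring carbons are inverted while the same atoms and bonds remain. For the measured compounds named here, no measured step in this set shows how such an inversion shifts growth inhibition, so the direction cannot be read from the data. A step beyond the usual scatter, in either direction, is considered possible, and a modest loss is expected, with a wide range around it. Compound 4 is estimated at 5500 nM, between 1500 nM and 25000 nM. The step from compound 1 to compound 4 that this estimate means is a 2.0-fold higher number from compound 1 to compound 4 (0.31 log units; beyond the scatter), expected rather than known.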

Compound 4, concentration for 50% growth inhibition: 1800 nM
Compound 4: middle estimate off by 3.1-fold (0.49 log units), on the high side; measured number inside the range.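

In this assay, for the compounds shown here, inverting the two stereocentres at saturated ring carbons gives a 1.5-fold lower number from compound 1 to compound 4 (0.18 log units; within the scatter), the first measured step in this set. With the atoms and bonds unchanged, the two configurations drawn at these ring carbons are not separated by growth inhibition, as the two numbers lie within the scatter of each other. Going by these compounds alone, compound 4 also joins compound 1 as a second compound with a number rather than a limit, and together they form the only pair here that differs in one place, which none of the earlier compounds could provide.

The compounds shown leave open whether inverting only one of the two stereocentres would give a different result, and compound 2 and compound 3 remain at limits and provide no step to set beside this one. They also leave open how growth inhibition would respond if the carboxylic acid were replaced by an amide or a primary alcohol, with the ring stereocentres held in either of the two configurations.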